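The source may report more compounds than this note shows. Statements on the series, on what has been measured and on what is new or still open speak of the compounds shown alone.

Measured so far in a physicochemical assay for lipophilicity; a lower number here means a more polar compound, a higher number a more lipophilic compound:

- Compound 1 `Ic1ccccc1-c1ncco1`: 2.3
- Compound 2 `FC(F)(F)c1ccccc1-c1ncco1`: 2.15

Within the data shown here, only one step has been measured, a number 0.15 log units lower from compound 1 to compound 2 (within the scatter). Among the measured compounds shown here, on these numbers, compound 2 therefore stands level with the only other measured compound. The next compound, compound 3 `O=[N+]([O-])c1ccccc1-c1ncco1`, keeps the shared core and changes one group nitro in place of trifluoromethyl on an aromatic carbon, ortho to a 1,3-oxazol-2-yl group.

For the measured compounds named here, the measured step is the only guide, and it bears on this change only loosely. Going by the values given here, it exchanged iodo for trifluoromethyl, and no measured compound carries a nitro. It shows that one exchange at this place left this assay within the scatter, but not that every exchange will. Here the entering group has hydrogen-bond acceptors and the leaving group has none. Starting from compound 2 at 2.15, a lower number is therefore expected, by more than the scatter, though the data do not fix the size. The step expected is a number 0.70 log units lower from compound 2 to compound 3 (beyond the scatter). The estimate for compound 3 is 1.45, within an expected range of 1 to 1.9.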

Compound 3, partition coefficient: 1.27
For compound 3 the middle estimate is 0.18 log units above the measured one; the measured number falls inside the stated range.
By their numbers in this assay, from the lowest: compound 3; then compounds 2 and 1 (each within the scatter of the next).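

In this assay, among these compounds, the earlier pair showed only that one exchange at this place, on an aromatic carbon ortho to a 1,3-oxazol-2-yl group, stayed within the scatter; the nitro compound shows that the group here can clearly move the number. Nitro in place of trifluoromethyl gives a number 0.88 log units lower from compound 2 to compound 3 (beyond the scatter), and nitro in place of iodo gives a number 1.03 log units lower from compound 1 to compound 3 (beyond the scatter), so both of the earlier groups part from nitro in the same direction, although they do not part from each other. Nitro is also the only one of the three groups that carries hydrogen-bond acceptors, but this is a coincidence of structure on the present data, and no measurement at hand explains the shift.

A single nitro compound cannot show whether the lower number belongs to nitro alone or extends to other groups with hydrogen-bond acceptors, such as a nitrile, a methoxy group or an amide. From the compounds shown here alone, whether nitro would give a step of similar size at another carbon of the ring, or on a different core, also remains open.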